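This account rests on a few compounds, and the source may have more. Where it says the series, first, only, none or still open, it means among the compounds named here.

The compounds share one core, seen in compound 1 `O/N=C(/Nc1ccc(F)c(F)c1)c1ccc2occc2c1`, compound 2 `O/N=C(/NCc1ccccc1)c1ccc2occc2c1` and compound 3 `O/N=C(/NCc1cccc(Cl)c1)c1ccc2occc2c1`; compound 4 `O/N=C(/NCc1ccc(F)c(Cl)c1)c1ccc2occc2c1` has not yet been tested. All three measured ones were examined in an assay on isolated protein for inhibition of Indoleamine 2,3-dioxygenase 1 (Homo sapiens), read by spectrophotometry; a higher number here means a weaker inhibitor, a lower number a stronger inhibitor. Compound 1 gives 22700 nM. For compound 2 the assay reports only a limit, > 30000 nM. Compound 3 likewise reaches only a limit, > 30000 nM, so its true potency is not pinned down by a number. The step from compound 2 to compound 3, a step that the two limits leave unreadable from compound 2 to compound 3, cannot be read because of the limit of > 30000 nM in this assay, at which 2 of the 3 values shown sit. Compound 4 differs from compound 3 by fluoro in place of hydrogen on an aromatic carbon. Among the compounds with values here, only one measured step is related to this change, and its size is unreadable, so there is no measured guide to how a second small halogen on this ring shifts the read-out; the only value given as a plain number is that of compound 1. The expectation is therefore that compound 4 stays near the limit, with an estimated value of 35000 nM, between 12000 nM and 100000 nM. The expected step that the limit leaves unreadable from compound 3 to compound 4 is none beyond the scatter, and most likely the assay again reports only a limit.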

Compound 4, half-maximal inhibitory concentration: 22000 nM
Beside the measured number, compound 4's estimate is 1.6-fold (0.20 log units) above it; measured number inside the range.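

In this assay, fluoro on the aromatic carbon ortho to a chloro group and para to a large group gives an at least 1.3-fold lower number from compound 3 to compound 4 (0.13 log units; that floor lies within the scatter). This change therefore turns a read-out that was only a limit into a plain number, which shows that this position of the ring can be altered without losing the signal altogether. The true size of the step cannot be read, however, and it may amount to no real gain, because compound 3 rests on a limit of the assay: the limit of > 30000 nM in this assay, at which 2 of the 4 values shown sit.

On these data alone, it remains open whether fluoro at this place would also give a plain number without the chloro group, or whether the two groups only work together. As far as these compounds go, it is equally open whether a different group on this carbon, such as methoxy, trifluoromethyl, an amine or a carboxylic acid, would lower the number by a step clearly beyond the scatter, which a firm statement about this position would require.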